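Swapping methyl for chloro in a chromone ester series

A few compounds are considered here, and "the series" means these few. Any claim that something is new, unique, unknown or untested is made for them only; others in the source may bear on it.

Two related compounds have been tested in an ADME assay on cells (T-cell, Mus musculus, strain BALB/c) for cytotoxicity, read by MTT assay, with a stated time of 48 h; on this read-out lower numbers stand for higher toxicity in this test and higher numbers for lower toxicity in this test. Compound 1 `COC(=O)c1c(Cl)cc(Cl)cc1OC(=O)COc1cc(O)c2c(=O)cc(-c3ccccc3)oc2c1` gives 345000 nM. Compound 2 `COC(=O)c1ccc(C)cc1OC(=O)COc1cc(O)c2c(=O)cc(-c3ccccc3)oc2c1` gives 250000 nM. These two numbers lie within the usual scatter of repeated measurements of each other, so they cannot be told apart on the numbers shown; compound 2 is simply one of two compounds that behave alike in this assay.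

Compound 3 `COC(=O)c1ccc(Cl)cc1OC(=O)COc1cc(O)c2c(=O)cc(-c3ccccc3)oc2c1` has not yet been measured. It differs from compound 2 in one place: chloro in place of methyl on an aromatic carbon, on an aromatic carbon of a six-membered aromatic ring of carbon only. Within the data shown here, no step between measured compounds is available for this change, so the expectation rests only on how close compound 1 and compound 2 sit. The expected step of a 1.1-fold higher number from compound 2 to compound 3 (0.05 log units; within the scatter) is small, with no direction that clearly goes beyond the scatter. Compound 3 is therefore estimated at about 280000 nM, within a range from 140000 nM to 560000 nM.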

Compound 3, half-maximal cytotoxic concentration: 265000 nM
Estimate against measurement, compound 3: 1.1-fold (0.02 log units) above; low and high end bracket the measured number.
By their numbers in this assay, from the lowest: compounds 2, 3 and 1 (each within the scatter of the next).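

At the aromatic carbon para to a methoxycarbonyl group, chloro and methyl can now be compared directly: in this assay this change gives a 1.1-fold higher number from compound 2 to compound 3 (0.03 log units; within the scatter), so the two groups cannot be told apart here. One chloro of compound 1 can also now be assessed on its own: replacing it with hydrogen gives a 1.3-fold lower number from compound 1 to compound 3 (0.11 log units; within the scatter), again within the scatter. Neither single change separates the compounds it connects, so at these positions the three compounds behave alike in this test.

On these data alone, whether a different kind of group at this position, such as an amine or a carboxylic acid, would move the number beyond the scatter remains open. No separate measurement is available to explain why these compounds behave alike.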